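Fluorine on the thiazole phenyl: notes on compound 4

The compounds below may be only part of what the source reports. "The series", "measured", "known", "first", "only" and "open" are said of these compounds alone.

Measured so far in a functional assay on HCT-116 cells (Homo sapiens) for inhibition, read by MTT assay, with a stated time of 48 h, tested at 2 uM; a higher number here means more inhibition at the concentration tested (going by the name of the read-out), a lower number less inhibition:
- compound 1 `Cc1noc(C)c1-c1ccc2c(c1)C(c1ccccc1)N(Cc1nnc(-c3ccccc3)o1)C(=O)N2C` gives 31.4%
- compound 2 `Cc1nc(-c2ccccc2)sc1CN1C(=O)N(C)c2ccc(-c3c(C)noc3C)cc2C1c1ccccc1` gives 28.3%
- compound 3 `Cc1noc(C)c1-c1ccc2c(c1)C(c1ccccc1)N(Cc1nc(-c3ccccc3)cs1)C(=O)N2C` gives 26.7%

The three measured compounds share a core and differ only in the heteroaryl group on the saturated chain carbon bound to the ring amide-type nitrogen. All three numbers sit close together: a number 3.1 percentage points lower from compound 1 to compound 2 (within the scatter), a number 4.7 percentage points lower from compound 1 to compound 3 (within the scatter) and a number 1.6 percentage points lower from compound 2 to compound 3 (within the scatter). Compound 2 stands second of the three, with compound 3 nearest and compound 1 furthest, and none of these gaps is beyond the scatter, so no ordering among them can be read.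

Compound 4 `Cc1nc(-c2ccc(F)cc2)sc1CN1C(=O)N(C)c2ccc(-c3c(C)noc3C)cc2C1c1ccccc1` has not yet been measured. It differs from compound 2 by fluoro in place of hydrogen on an aromatic carbon.

Within the data shown here, none of the measured steps touches this change; each exchanges the whole heteroaryl group, and none alters the phenyl on it. Among the measured compounds shown here, the only guidance is that every measured exchange in this small set, including the larger ones, stayed within the scatter. On that basis a step within the scatter is expected for compound 4 as well, with no direction favoured, and the number expected for compound 4 is 28%, between 16% and 40%, which means an estimated step of a number 0.3 percentage points lower from compound 2 to compound 4 (within the scatter).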

Compound 4, a percentage reported as inhibition, at one concentration (the size of the read-out at that concentration, not a potency): 26%
Compound 4: the middle estimate sits 2 percentage points above what was measured; measured number inside the range.
By their numbers in this assay, from the lowest: compounds 4, 3, 2 and 1 (each within the scatter of the next).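

Unlike the earlier steps, which exchange the whole heteroaryl group, this one alters only the phenyl carried on that group: in this assay, phenyl to 4-fluorophenyl gives a number 2.3 percentage points lower from compound 2 to compound 4 (within the scatter) and thus adds a single-atom change to the set. Among these compounds, at this aromatic carbon, para to a large group, fluoro in place of hydrogen therefore gives no step that can be read beyond the scatter, so the series so far shows no sensitivity to this change at the one concentration tested. Nothing available offers an explanation for this result.

Open, as far as these compounds go, is whether any other group at this carbon would give a step beyond the scatter: one fluoro is a very small probe, and an amine, a carboxylic acid or a methoxy group in the same place would test the position more widely. Also open, from the compounds shown here alone, is whether fluoro on the phenyl of the 5-phenyl-1,3,4-oxadiazol-2-yl group of compound 1 would behave as it does here, and how these compounds compare as full concentration-response curves, since a single-concentration read-out is not a potency.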